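Thiophene Returns in Place of Furan on the Spiro Lactam Core

This account rests on a few compounds, and the source may have more. Where it says the series, first, only, none or still open, it means among the compounds named here.

Compound 3 `Cc1ccc(-c2cncc(Cl)c2N2CCC3(CCNC3=O)CC2)o1` stands at the weak end of the three compounds measured in a functional assay on MV4-11 cells (Homo sapiens) for inhibition, read by resazurin assay, with a stated time of 72 h; on this read-out higher numbers stand for weaker inhibition of growth and lower numbers for stronger inhibition of growth: compound 3 gives 4950 nM, the highest of the three numbers. Compound 1 `O=C1NCCC12CCN(c1c(Cl)cncc1-c1cccs1)CC2` gives 480 nM in this assay, and compound 2 `O=C1NCCC12CCN(c1c(Cl)cncc1-c1ccsc1)CC2` gives 190 nM. Both steps onto compound 3 are large: a 10-fold higher number from compound 1 to compound 3 (1.01 log units; beyond the scatter) and a 26-fold higher number from compound 2 to compound 3 (1.42 log units; beyond the scatter). The step within the thiophenyl pair, a 2.5-fold lower number from compound 1 to compound 2 (0.40 log units; beyond the scatter), is modest by comparison.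

Compound 4 `Cc1ccsc1-c1cncc(Cl)c1N1CCC2(CCNC2=O)CC1` has not been measured in this assay. It differs from compound 3 in one place: 3-methylthiophen-2-yl in place of 5-methylfuran-2-yl on an aromatic carbon. The entering group is the thiophen-2-yl of compound 1 with an added methyl, so the step of a 10-fold higher number from compound 1 to compound 3 (1.01 log units; beyond the scatter) bears on it most directly, read in reverse, and a 26-fold higher number from compound 2 to compound 3 (1.42 log units; beyond the scatter) points the same way. Among the measured compounds shown here, no measured compound carries a methyl on the thiophene, so the contribution of that methyl is unknown, and the swap of a sulfur-containing ring for an oxygen-containing ring is the only part of the change with a precedent.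

Compound 4 is therefore expected to show an 8.3-fold lower number from compound 3 to compound 4 (0.92 log units; beyond the scatter) in this assay, a large step toward stronger inhibition of growth. The estimate for compound 4 is 600 nM, with a range from 200 nM to 2500 nM.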

Compound 4, concentration for 50% growth inhibition: 910 nM
The estimate for compound 4 lay 1.5-fold (0.18 log units) below the measured number; the range from low to high includes it.
By their numbers in this assay, from the lowest: compound 2; then compounds 1 and 4 (each within the scatter of the next); then compound 3.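

In this assay, placing 3-methylthiophen-2-yl in position of 5-methylfuran-2-yl on this aromatic carbon, ortho to a large group, gives a 5.4-fold lower number from compound 3 to compound 4 (0.74 log units; beyond the scatter), so a methyl on the five-membered ring does not by itself go with the weak number of compound 3. Methyl in place of hydrogen on the thiophen-2-yl ring gives a 1.9-fold higher number from compound 1 to compound 4 (0.28 log units; within the scatter), which means that this first methylated thiophene cannot be told apart from its unmethylated parent in this read-out. Thiophen-3-yl still holds the lowest number of the four, as a 4.8-fold higher number from compound 2 to compound 4 (0.68 log units; beyond the scatter) shows, although that step combines the added methyl with a different point of attachment to the thiophene, and the two contributions cannot be separated here.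

No measurement available here explains the difference between the furan and thiophene groups at this position. Going by these compounds, it also remains open how this assay would respond to 5-methylthiophen-2-yl, which would put the methyl where the furan of compound 3 carries it, or to a methoxy group or an amine on the thiophene ring.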